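The source may report more compounds than this note shows. Statements on the series, on what has been measured and on what is new or still open speak of the compounds shown alone.

Compound 1, `CN(C)CCC(=O)c1cc2ccc(O)cc2oc1=O`: in an assay on cells for inhibition of Amine oxidase [flavin-containing] B (Homo sapiens), read by fluorescence, spectrophotometry and Amplex Red, with stated times of 60 min and 30 min (on this read-out lower numbers stand for stronger inhibition and higher numbers for weaker inhibition), compound 1 gives 71400 nM.
Compound 2, `O=C(CCN1CCCC1)c1cc2ccc(O)cc2oc1=O`: in this assay compound 2 gives > 200000 nM, a limit of the assay and not a number.
Compound 3, `COc1ccc2cc(C(=O)CCN(C)C)c(=O)oc2c1`: in this assay compound 3 gives 21100 nM.

Compound 1 holds the highest of the two numbers shown; its nearest neighbour is compound 3, reached by the step of a 3.4-fold lower number from compound 1 to compound 3 (0.53 log units; beyond the scatter), which is modest. The value of compound 2 is the limit of > 200000 nM in this assay, at which 1 of the 3 values shown sits, a limit and not a number.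

Compound 4, `Cc1cc(O)cc2oc(=O)c(C(=O)CCN(C)C)cc12`, differs from compound 1 by methyl in place of hydrogen on an aromatic carbon. Neither measured step repeats this change. The step of an at least 2.8-fold higher number from compound 1 to compound 2 (0.44 log units; beyond the scatter) alters the amine on the chain and leaves the rings untouched. The step of a 3.4-fold lower number from compound 1 to compound 3 (0.53 log units; beyond the scatter) also brings in a methyl, but on the oxygen of the hydroxy group rather than on an aromatic carbon, so it is at best a loose guide. With nothing closer to lean on, a step within the scatter, or at most a small one in either direction, is expected in this assay. Compound 4 is therefore estimated at 55000 nM, with a range from 15000 nM to 160000 nM. This estimate corresponds to the step of a 1.3-fold lower number from compound 1 to compound 4 (0.11 log units; within the scatter), which is expected to be small.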

Compound 4, half-maximal inhibitory concentration: 3660 nM
Compound 4: middle estimate off by 15-fold (1.18 log units), on the high side; the whole stated range lies above it.
By their numbers in this assay, from the lowest: compound 4; then compound 3; then compound 1. At a limit, above all of these: compound 2.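

In this assay, the aromatic carbon that takes the new methyl, on the six-membered aromatic ring of carbon only and meta to a hydroxy group, proves to be a place where one small change counts heavily: a 20-fold lower number from compound 1 to compound 4 (1.29 log units; beyond the scatter). The earlier compounds shown here had altered only the amine on the chain and the oxygen on the aromatic ring, and the methyl on that oxygen gave a much smaller change, a 3.4-fold lower number from compound 1 to compound 3 (0.53 log units; beyond the scatter), so they gave no sign that this ring carbon would respond so strongly. Nothing in the data on hand accounts for the size of this step.

On these data alone, whether the gain belongs to methyl itself or would also appear with another group on this carbon, such as a chlorine atom, an ethyl or a methoxy, remains open, as does the effect of a methyl on the other aromatic carbons of the ring. Also open, as far as these compounds go, is whether this methyl would combine with the methyl on the oxygen of compound 3, or hold with the pyrrolidin-1-yl group of compound 2.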